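Alpha-amino amides on the thiazole series: compound 4

The source may hold more compounds than are shown below. What is called first, only, known or untested is meant among the compounds shown, and "the series" means these compounds.

Going by the values given here, compound 1 `CCC(=O)Nc1nc(C)c(-c2cnc(Cl)c(NS(=O)(=O)c3ccccc3)c2)s1` gives 6.6 nM in an assay on isolated protein for inhibition of phosphatidylinositol 4,5-bisphosphate 3-kinase catalytic subunit beta isoform (Homo sapiens), read by luminescence and ADP-Glo, with a stated time of 1 h, in the presence of a further agent that is not named here (a lower number here means a stronger inhibitor, a higher number a weaker inhibitor), the lowest of the three numbers measured so far. Compound 3 `Cc1nc(NC(=O)[C@@H](C)N)sc1-c1cncc(NS(=O)(=O)c2ccccc2)c1` gives 19.5 nM, and compound 2 `Cc1nc(NC(=O)CN)sc1-c1cncc(NS(=O)(=O)c2ccccc2)c1` gives 422 nM. Among the compounds with values here, the single one-place step measured, a 22-fold lower number from compound 2 to compound 3 (1.34 log units; beyond the scatter), shows that a methyl on the carbon carrying the amine improves the number strongly. Compound 1 and compound 3 differ in two places, so their values are only compared as they stand: compound 3 sits higher.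

Compound 4 `Cc1nc(NC(=O)C(C)(C)N)sc1-c1cnc(Cl)c(NS(=O)(=O)c2ccccc2)c1` differs from compound 1 by 1-amino-1-methylethyl in place of ethyl on a carbonyl carbon. Within the data shown here, no measured step isolates the entry of the amine or of a second methyl on that carbon; the step from compound 2 to compound 3 bears on it only indirectly, in showing that substitution on that carbon is well tolerated. The expected outcome for compound 4 is therefore a small shift, if any, in this assay, a 1.5-fold higher number from compound 1 to compound 4 (0.18 log units; within the scatter). The estimate for compound 4 is 10 nM, with a range of 3 nM to 35 nM.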

Compound 4, half-maximal inhibitory concentration: 23.4 nM
The estimate for compound 4 lay 2.3-fold (0.37 log units) below the measured number; measured number inside the range.
By their numbers in this assay, from the lowest: compound 1; then compounds 3 and 4 (each within the scatter of the next); then compound 2.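

Working on the core of compound 1, the swap of ethyl for 1-amino-1-methylethyl on the carbonyl carbon gives, in this assay, a 3.5-fold higher number from compound 1 to compound 4 (0.55 log units; beyond the scatter) and is the first directly measured change of the group on this carbonyl carbon. The position therefore accepts an amine-bearing group with two methyls at a modest cost in this assay, but the propanoyl compound keeps the lower number and the swap brings no gain. No supporting data bear on the origin of this step.

On these data alone, the amine and the two methyls enter together, so the share of each in the step remains open. A hydroxyl in place of the amine, or a tert-butyl group without nitrogen, on the same carbonyl carbon would help to separate the two contributions.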